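This account rests on a few compounds, and the source may have more. Where it says the series, first, only, none or still open, it means among the compounds named here.

The study compares four compounds that share one core. Compound 3 `COc1ccc(-c2cn(-c3cccc(C(=O)/C=C/c4cc(OC)c(OC)c(OC)c4)c3)c(=O)[nH]2)cc1` carries a 3,4,5-trimethoxyphenyl group on its chain, and compound 1 `COc1cc(/C=C/C(=O)c2cccc(-n3cc(-c4ccc(Cl)cc4)[nH]c3=O)c2)cc(OC)c1OC` differs from it by chloro in place of methoxy on an aromatic carbon. In a functional assay on SK-MEL-28 cells (Homo sapiens) for inhibition (a higher number here means a weaker inhibitor of growth, a lower number a stronger inhibitor of growth), compound 3 gives 2030 nM, whereas compound 1 gives 10900 nM, so that a 5.4-fold higher number from compound 3 to compound 1 (0.73 log units; beyond the scatter). Compound 2 `COc1ccc(-c2cn(-c3cccc(C(=O)/C=C/c4ccc(O)c(OC)c4)c3)c(=O)[nH]2)cc1` differs from compound 3 by 4-hydroxy-3-methoxyphenyl in place of 3,4,5-trimethoxyphenyl on a double-bonded chain carbon bound to a double-bonded chain carbon, and in this assay compound 2 gives 2030 nM; accordingly no change at the digits printed from compound 2 to compound 3 (within the scatter). Compound 4 `COc1cc(/C=C/C(=O)c2cccc(-n3cc(-c4ccc(Cl)cc4)[nH]c3=O)c2)ccc1O` has not yet been measured in this assay. It differs from compound 2 by chloro in place of methoxy on an aromatic carbon, which is the same change, at the same place, that was made from compound 3 to compound 1. Because a 5.4-fold higher number from compound 3 to compound 1 (0.73 log units; beyond the scatter) lay beyond the scatter, and because no change at the digits printed from compound 2 to compound 3 (within the scatter), compound 4 is expected to move by a step of similar size, a 5.2-fold higher number from compound 2 to compound 4 (0.71 log units; beyond the scatter). The estimate for compound 4 in this assay is therefore 10500 nM, expected to fall between 4500 nM and 25000 nM.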

Compound 4, concentration for 50% growth inhibition: 2060 nM
Compound 4: the middle estimate sits 5.1-fold (0.71 log units) above what was measured, and the stated range ends above it.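

In this assay, the swap of 4-methoxyphenyl to 4-chlorophenyl on the core carrying 4-hydroxy-3-methoxyphenyl gives a 1.0-fold higher number from compound 2 to compound 4 (0.01 log units; within the scatter). Set beside the earlier step on the core carrying 3,4,5-trimethoxyphenyl, the same change does not carry over at the same size: the same change on two cores in this assay, a 5.4-fold higher number (0.73 log units; beyond the scatter) from compound 3 to compound 1 and a 1.0-fold higher number (0.01 log units; within the scatter) from compound 2 to compound 4, 5.3-fold (0.72 log units) apart, beyond the scatter of two such steps. Among these compounds, this shows that, for these two pairs, the size of the step from methoxy to chloro cannot be transferred from one core to the other, but it does not show what makes the two steps part, and with only two pairs it sets no rule for the wider series.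

The compounds shown leave open how the same change would read with other groups on the chain's aromatic ring, such as an amine or a carboxylic acid. They also leave open whether a fluoro or a methyl in place of the chloro would part between the two cores in the same way.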